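Amine variation at the glycine carbonyl, thyroid receptor alpha

The compounds below may be only part of what the source reports. "The series", "measured", "known", "first", "only" and "open" are said of these compounds alone.

The series keeps the core shown in compound 1 `CS(=O)(=O)c1ccc(C(=O)NCC(=O)N(Cc2ccccc2)Cc2ccccc2)cc1[N+](=O)[O-]` and varies the amine on the glycine carbonyl. In an assay on isolated protein for inhibition of thyroid hormone receptor alpha (Homo sapiens), read by fluorescence polarization (a lower number here means a stronger inhibitor, a higher number a weaker inhibitor), compound 1 gives 1700 nM. Compound 2 `CN(Cc1ccccc1F)C(=O)CNC(=O)c1ccc(S(C)(=O)=O)c([N+](=O)[O-])c1` returns only a limit in this assay, > 60000 nM. Compound 3 `CC(C)N(C(=O)CNC(=O)c1ccc(S(C)(=O)=O)c([N+](=O)[O-])c1)C(C)C` also returns only a limit in this assay, > 60000 nM. Compound 3 therefore sits at the limit of > 60000 nM in this assay, at which 2 of the 3 values shown sit, the weak end of the numbers shown. Compound 4 `CN(Cc1ccccc1)C(=O)CNC(=O)c1ccc(S(C)(=O)=O)c([N+](=O)[O-])c1` is not yet measured; it carries benzyl(methyl)amino in place of diisopropylamino on a carbonyl carbon. Compound 4 is structurally close to compound 2, which reaches only a limit here, and the step from compound 3 to compound 4 is expected to be an at least 1.2-fold lower number from compound 3 to compound 4 (0.07 log units; that floor lies within the scatter), nothing beyond the scatter. Compound 4 is estimated at 50000 nM, within 8000 nM to 250000 nM, most likely again reported only as a limit.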

Compound 4, half-maximal inhibitory concentration: > 60000 nM
Compound 4: only a limit was reported; the forecaster's own chance of this, stated with the estimate: 65%; middle value at least 1.2-fold (0.07 log units) from the limit.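

Swapping one phenyl of compound 1 for hydrogen, which leaves benzyl(methyl)amino on the carbonyl carbon, gives an at least 35-fold higher number from compound 1 to compound 4 (1.54 log units; beyond the scatter) in this assay. A single benzyl group on this amine is therefore not enough for a readable value here, even without the fluoro of compound 2. The steps to compound 4 from compound 2 and compound 3 cannot be read: the limit of > 60000 nM in this assay, at which 3 of the 4 values shown sit.

From the compounds shown here alone, whether phenethyl in place of the methyl would recover a readable value remains open. So does whether cyclohexylmethyl could stand in for either benzyl group of compound 1.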